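Replacing 3,4-dihydroxyphenyl with 3,5-dimethylphenyl: an expected step

The source may hold more compounds than are shown below. What is called first, only, known or untested is meant among the compounds shown, and "the series" means these compounds.

Compound 1 `CCC1=C(O)c2c(oc(-c3cccc(OC)c3)cc2=O)C(CC)(CC)C1=O`: 13.3 uM
Compound 2 `CCC1=C(O)c2c(oc(-c3ccc(O)c(O)c3)cc2=O)C(CC)(CC)C1=O`: 10 uM

These values come from a functional assay on KB cells (Homo sapiens) for antiproliferative activity, read by sulforhodamine B assay, with a stated time of 3 days; a lower number here means that less compound is needed, a higher number that more compound is needed for the effect. There, compound 2 stands within the usual scatter of compound 1, so neither can be ranked above the other. The unmeasured compound 3 `CCC1=C(O)c2c(oc(-c3cc(C)cc(C)c3)cc2=O)C(CC)(CC)C1=O` differs from compound 2 at one place: 3,5-dimethylphenyl in place of 3,4-dihydroxyphenyl on an aromatic carbon. Within the data shown here, only one measured step bears on this, and it changes the same aromatic group: a 1.3-fold lower number from compound 1 to compound 2 (0.12 log units; within the scatter). That single step is thin evidence, but it gives no reason to expect a change beyond the scatter in this assay. The expected size of the change is a 1.2-fold higher number from compound 2 to compound 3 (0.08 log units; within the scatter). For compound 3 the estimated value is 12 uM, within an expected range of 5 uM to 30 uM.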

Compound 3, concentration for half-maximal effect: 45.5 uM
For compound 3 the middle estimate is 3.8-fold (0.58 log units) below the measured one; measured number above the stated range.
By their numbers in this assay, from the lowest: compounds 2 and 1 (each within the scatter of the next); then compound 3.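

This position is not indifferent: in this assay, changing the aromatic group moves the number beyond the scatter, with a 4.6-fold higher number from compound 2 to compound 3 (0.66 log units; beyond the scatter) and a 3.4-fold higher number from compound 1 to compound 3 (0.53 log units; beyond the scatter). Among these three compounds, the two phenyl groups bearing oxygen give the lower numbers, and 3,5-dimethylphenyl, with carbon only, gives the higher one. Nothing measured here gives a reason for this difference. The compounds shown leave open whether the loss of oxygen or the gain of methyl groups matters more. On these data alone, how a phenyl ring carrying an amine or a carboxylic acid would behave at this place also stays open.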